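Benzoyl in place of cyclobutylcarbonyl: solubility at the ceiling

The source may report more compounds than this note shows. Statements on the series, on what has been measured and on what is new or still open speak of the compounds shown alone.

Compound 1, `CC1(C)c2[nH]nc(NC(=O)c3ccc(F)cc3)c2CN1C(=O)C1CCN(C2CC2)CC1`: > 225000 nM
Compound 2, `CN1CCC(C(=O)N2Cc3c(NC(=O)C4CCC4)n[nH]c3C2(C)C)CC1`: > 225000 nM
Compound 3, `CC(C)CC(=O)Nc1n[nH]c2c1CN(C(=O)C1CCN(C3CC3)CC1)C2(C)C`: > 225000 nM

In a physicochemical assay for solubility, at pH 7 (on this read-out lower numbers stand for lower solubility and higher numbers for higher solubility), compound 1 reports only a limit, not a number. Compound 3 likewise stops at a limit. Compound 2 also gives a limit and nothing more. The step that the two limits leave unreadable from compound 1 to compound 3 cannot be read because of the limit of > 225000 nM in this assay, at which 3 of the 3 values shown sit. Compound 4, `CN1CCC(C(=O)N2Cc3c(NC(=O)c4ccccc4)n[nH]c3C2(C)C)CC1`, differs from compound 2 by phenyl in place of cyclobutyl on a carbonyl carbon. Within the data shown here, no measured step gives a readable size, and every value shown sits at the same limit, so nothing points to a change beyond the scatter. Compound 4 is therefore expected at 250000 nM, most likely again as a limit. Its range is estimated from 80000 nM to 600000 nM. The expected step is a step that the limit leaves unreadable from compound 2 to compound 4.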

Compound 4, solubility: > 225000 nM
Compound 4: only a limit was reported (the forecaster's own chance of this, stated with the estimate: 75%); the middle value lies beyond the limit too.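

No size can be read for the step between compound 2 and compound 4, because both values are limits and not numbers: the limit of > 225000 nM in this assay, at which 4 of the 4 values shown sit. The compounds shown leave open whether any of these changes shifts the read-out at all, and in which direction.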